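This account rests on a few compounds, and the source may have more. Where it says the series, first, only, none or still open, it means among the compounds named here.

Measured compounds in the series:

Compound 1 `Cc1c(C(=O)Nc2ccc(Oc3ncnc4[nH]cc(-c5ccccc5)c34)c(F)c2)c(=O)c2cc(F)ccc2n1C`. In an assay on isolated protein for inhibition of tyrosine-protein kinase receptor UFO (Homo sapiens), read by FRET and Z'-LYTE, with a stated time of 1.5 h (a higher number here means a weaker inhibitor, a lower number a stronger inhibitor), compound 1 gives > 10000 nM, which is a limit of the assay and not a number.
Compound 2 `Cc1c(C(=O)Nc2ccc(Oc3ncnc4[nH]cc(-c5ccccc5)c34)c(F)c2)c(=O)c2cc(C(F)(F)F)ccc2n1C`. In this assay compound 2 gives 150 nM.
Compound 3 `Cc1c(C(=O)Nc2ccc(Oc3ncnc4[nH]cc(-c5ccccc5)c34)c(F)c2)c(=O)c2cc(C3CC3)ccc2n1C`. In this assay compound 3 gives 230 nM.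

Compound 3 stands among the two numbered values with compound 2 as its nearest neighbour; the pair lie within the scatter of each other, the step being a 1.5-fold higher number from compound 2 to compound 3 (0.19 log units; within the scatter). The only limit in the set is that of compound 1 (the limit of > 10000 nM in this assay, at which 1 of the 3 values shown sits).

Compound 4 `C=C(C)c1ccc2c(c1)c(=O)c(C(=O)Nc1ccc(Oc3ncnc4[nH]cc(-c5ccccc5)c34)c(F)c1)c(C)n2C` differs from compound 3 by 1-methylethenyl in place of cyclopropyl on an aromatic carbon. Within the data shown here, no measured step tests 1-methylethenyl at this position. Among the measured compounds shown here, the steps that bear on it are those at the same aromatic carbon: an at least 43-fold lower number from compound 1 to compound 3 (1.63 log units; beyond the scatter) and an at least 66-fold lower number from compound 1 to compound 2 (1.82 log units; beyond the scatter), both large, and a 1.5-fold higher number from compound 2 to compound 3 (0.19 log units; within the scatter), within the scatter. Two groups of similar size at this carbon give numbers within the scatter of each other, while fluoro leaves only a limit. A third group of the same size is therefore expected to give a number close to that of compound 3, with no step beyond the scatter: the expected step in this assay is a 1.1-fold higher number from compound 3 to compound 4 (0.04 log units; within the scatter).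

For compound 4 the estimated value in this assay is 250 nM, within a range of 100 nM to 700 nM.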

Compound 4, half-maximal inhibitory concentration: 170 nM
Beside the measured number, compound 4's estimate is 1.5-fold (0.17 log units) above it, and the stated range covers the measured number.
By their numbers in this assay, from the lowest: compounds 2, 4 and 3 (each within the scatter of the next). At a limit, above all of these: compound 1.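

In this assay, replacing the ring of compound 3 with an open group bearing a double bond gives a 1.4-fold lower number from compound 3 to compound 4 (0.13 log units; within the scatter), and the comparison with trifluoromethyl gives a 1.1-fold higher number from compound 2 to compound 4 (0.05 log units; within the scatter), so a three-membered non-aromatic ring of carbon only is not required at this aromatic carbon. Against fluoro the step is an at least 58-fold lower number from compound 1 to compound 4 (1.76 log units; beyond the scatter), which makes 1-methylethenyl the third group, after trifluoromethyl and cyclopropyl, to stand clear of fluoro, while these three remain within the scatter of one another. Compound 1 supplies a limit of the assay and not a number, so every step from it gives only a minimum size: the limit of > 10000 nM in this assay, at which 1 of the 4 values shown sits.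

The compounds shown leave open whether the three-carbon and trifluoromethyl results extend to groups of another kind at this carbon, such as an amine, a carboxylic acid, a methoxy group or a longer chain such as n-butyl. They also leave open how a plain hydrogen or a chloro group at this carbon would compare in this assay, and so whether fluoro is an isolated case or part of a wider trend.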